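Removing the Benzyl from a Hydroxamic Acid Pair

This account rests on a few compounds, and the source may have more. Where it says the series, first, only, none or still open, it means among the compounds named here.

Two compounds have numbers in an ADME assay on a cell-free system (plasma, Rattus norvegicus, strain Sprague-Dawley) for metabolic stability, read by LC-MS, tested at 10 uM; a lower number here means that the compound disappears faster, a higher number that the compound lasts longer. Compound 1 `CC1(C)ON=C(C(Cc2ccccc2)C(=O)NCc2ccc(F)cc2)O1` gives 1 h in this assay. Compound 2 `CC(Cc1ccccc1)(C(=O)NO)C(=O)NCc1ccc(F)cc1` gives 3.6 h in this assay, the higher of the two numbers, and its gap to compound 1 lies beyond the scatter. Compound 3 `CC(C(=O)NO)C(=O)NCc1ccc(F)cc1` has not yet been measured in this assay. It differs from compound 2 in one place: hydrogen in place of benzyl on a saturated chain carbon bound to two carbonyl carbons and a saturated chain carbon. Within the data shown here, no step between measured compounds carries this same change, so the size of the step can only be guessed from the two numbers at hand. The expected step of a 1.8-fold lower number from compound 2 to compound 3 (0.26 log units; within the scatter) is a modest fall, of a size that may stay close to the scatter. Compound 3 is therefore estimated at 2 h in this assay, within a range from 0.8 h to 5 h.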

Compound 3, half-life: 33 h
Compound 3: middle estimate off by 17-fold (1.22 log units), on the low side; the whole stated range lies below it.
By their numbers in this assay, from the lowest: compound 1; then compound 2; then compound 3.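

In this assay, among these compounds, hydrogen in place of benzyl on a saturated chain carbon bound to two carbonyl carbons and a saturated chain carbon gives a 9.2-fold higher number from compound 2 to compound 3 (0.96 log units; beyond the scatter), the first single change for which a step can be read. It shows that the group on this carbon has a large bearing on how long the compound lasts, and that here the benzyl goes with the shorter-lived compound of the pair. No measurement shown here explains the rise.

This is a single step, so it cannot say whether the rise follows the aromatic ring or the chain carbons of the benzyl. Phenyl, ethyl or a longer chain such as phenethyl on the same carbon would be needed to separate the two, and how each would fall relative to this step remains open.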